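Swapping tert-butyl for methylsulfanyl in compound 3

A few compounds are considered here, and "the series" means these few. Any claim that something is new, unique, unknown or untested is made for them only; others in the source may bear on it.

Of the compounds shown here, three sharing one core have been measured in a physicochemical assay for solubility, at pH 7.4; a lower number here means a less soluble compound, a higher number a more soluble compound. Compound 1 `Cc1cc(NC(=O)Nc2ccccc2OC(F)(F)F)c2ccccc2n1` gives 4600 nM, compound 2 `Cc1cc(NC(=O)Nc2ccccc2N)c2ccccc2n1` gives 51800 nM, and compound 3 `Cc1cc(NC(=O)Nc2ccccc2C(C)(C)C)c2ccccc2n1` gives 100 nM, the lowest number of the three. The next compound, compound 4 `CSc1ccccc1NC(=O)Nc1cc(C)nc2ccccc12`, carries methylsulfanyl in place of tert-butyl on an aromatic carbon.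

Two measured steps bring tert-butyl onto that same carbon: a 46-fold lower number from compound 1 to compound 3 (1.66 log units; beyond the scatter) and a 520-fold lower number from compound 2 to compound 3 (2.71 log units; beyond the scatter). Both are large, so taking tert-butyl away should raise the number in this assay. Among the compounds with values here, no measured compound carries methylsulfanyl, however, which leaves the size of the rise uncertain. The amino group of compound 2 sits far up, as an 11-fold higher number from compound 1 to compound 2 (1.05 log units; beyond the scatter) shows, and a rise that far is not assumed. Compound 1 serves as the closer guide.

The expected change is large: a 30-fold higher number from compound 3 to compound 4 (1.48 log units; beyond the scatter). For compound 4 the estimated value is 3000 nM, with an expected range of 700 nM to 12000 nM.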

Compound 4, solubility: 21000 nM
The estimate for compound 4 lay 7.0-fold (0.85 log units) below the measured number, outside the stated range (above it).
By their numbers in this assay, from the lowest: compound 3; then compound 1; then compound 4; then compound 2.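

In this assay, within the data shown here, the change from tert-butyl to methylsulfanyl on this aromatic carbon gives a 210-fold higher number from compound 3 to compound 4 (2.32 log units; beyond the scatter) and is the first measured step to show how far a sulfur-bearing group lifts the number here. Compound 4 also moves past the trifluoromethoxy compound, with a 4.6-fold higher number from compound 1 to compound 4 (0.66 log units; beyond the scatter) and so a higher reading than that guide alone suggested. It still does not reach the amino compound, with a 2.5-fold lower number from compound 2 to compound 4 (0.39 log units; beyond the scatter) and so a place between these two groups in the order of the four compounds.

No measurement shown gives a reason for these steps. It remains open where methoxy, the oxygen counterpart of methylsulfanyl, or ethylsulfanyl, a longer chain on the same sulfur, would fall among these four compounds in this assay on this same carbon.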